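Hydroxy for Fluoro on a Shared Cytotoxic Core

The source may hold more compounds than are shown below. What is called first, only, known or untested is meant among the compounds shown, and "the series" means these compounds.

Measured compounds:
compound 1 `O=C1/C(=C\c2cccc(Oc3ccccc3)c2)c2ccccc2N1c1c(Cl)cccc1Cl`: 5 ug/mL
compound 2 `O=C1/C(=C\c2ccc(F)cc2)c2ccccc2N1c1c(Cl)cccc1Cl`: 5 ug/mL

In a functional assay on KB cells (Homo sapiens) for cytotoxicity, read by MTT assay, with a stated time of 72 h (on this read-out higher numbers stand for an effect only at larger amounts of compound and lower numbers for an effect already at smaller amounts), compound 1 gives 5 ug/mL. Compound 2, in this assay, gives 5 ug/mL, level with compound 1 at the digits shown; the two values sit within the scatter of each other, so nothing separates them. Compound 3 `O=C1/C(=C\c2ccc(O)cc2)c2ccccc2N1c1c(Cl)cccc1Cl` has not yet been tested in this assay. It differs from compound 2 in one place: hydroxy in place of fluoro on an aromatic carbon. Among the compounds with values here, the two measured compounds give no step of this kind to lean on, so the size of the change cannot be read from them. The expectation is a step of a 1.2-fold higher number from compound 2 to compound 3 (0.08 log units; within the scatter), that is, none beyond the scatter, with compound 2 at 5 ug/mL as the anchor. On that basis compound 3 is estimated at 6 ug/mL in this assay, expected to fall between 2 ug/mL and 20 ug/mL.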

Compound 3, concentration for half-maximal effect: 2 ug/mL
Estimate against measurement, compound 3: 3.0-fold (0.48 log units) above; the range from low to high includes it.
By their numbers in this assay, from the lowest: compound 3; then compounds 1 and 2 (each within the scatter of the next).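

In this assay, hydroxy in place of fluoro on an aromatic carbon, para to a large group, gives a 2.5-fold lower number from compound 2 to compound 3 (0.40 log units; beyond the scatter). Within the data shown here, this is the first step that can be read, and it shows that this position responds to this change by more than the scatter, which the values of compound 1 and compound 2 alone could not show. Nothing available explains the lower number with the hydroxy group, and the finding rests on this single pair, 4-fluorophenyl to 4-hydroxyphenyl.

The compounds shown leave open whether an amine or a methoxy group at the same place would give a similar step, or whether a carboxylic acid there would lower the number further. They also leave open whether a hydroxy group would have a similar effect on the phenoxy-bearing ring of compound 1.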